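A few compounds are considered here, and "the series" means these few. Any claim that something is new, unique, unknown or untested is made for them only; others in the source may bear on it.

In an ADME assay (liver) for metabolic stability, with Liver microsome (Rattus norvegicus) as the target, using microsomes and NADPH, with a stated time of 30 min, tested at 1 uM (a higher number here means faster removal of the compound, a lower number slower removal), compound 2 `COc1cc(C(O)(C(F)(F)F)C(F)(F)F)cnc1N1CCN(S(=O)(=O)c2ccc(N)nc2)CC1` gives < 14 mL.min-1.g-1, which is a limit of the assay and not a number. Compound 1 `Nc1ccc(S(=O)(=O)N2CCN(c3ncc(C(O)(C(F)(F)F)C(F)(F)F)cc3Br)CC2)cn1` gives 32 mL.min-1.g-1 in this assay. Among the compounds with values here, the one measured step is an at least 2.2-fold lower number from compound 1 to compound 2 (0.35 log units; beyond the scatter), with methoxy in place of bromo on an aromatic carbon. Compound 3 `Nc1ccc(S(=O)(=O)N2CCN(c3ncc(C(O)(C(F)(F)F)C(F)(F)F)cc3C3CC3)CC2)cn1` changes the same place, with cyclopropyl in place of methoxy on an aromatic carbon. Compound 3 gives up the methoxy that came with an at least 2.2-fold lower number from compound 1 to compound 2 (0.35 log units; beyond the scatter), so a higher number of similar size is expected in this assay. The expected change is an at least 2.0-fold higher number from compound 2 to compound 3 (0.30 log units; that floor lies within the scatter). For compound 3 the estimate is 28 mL.min-1.g-1, with a range of 14 mL.min-1.g-1 to 60 mL.min-1.g-1.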

Compound 3, intrinsic clearance in microsomes: 27 mL.min-1.g-1
Beside the measured number, compound 3's estimate is 1.0-fold (0.02 log units) above it; low and high end bracket the measured number.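

In this assay, cyclopropyl in place of methoxy on this aromatic carbon gives an at least 1.9-fold higher number from compound 2 to compound 3 (0.28 log units; that floor lies within the scatter). Cyclopropyl in place of bromo gives a 1.2-fold lower number from compound 1 to compound 3 (0.07 log units; within the scatter), so these two groups cannot be told apart at this position, though they differ in ring and atoms. As far as these compounds go, how large the step from methoxy really is stays open, as the value of compound 2 is a limit of the assay and not a number: the limit of < 14 mL.min-1.g-1 in this assay, at which 1 of the 3 values shown sits. Whether an ethoxy group or an amine on this carbon would stay as low as methoxy also remains open.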